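Thiocarbonyl ring swap from compound 3 to compound 4

The compounds below may be only part of what the source reports. "The series", "measured", "known", "first", "only" and "open" are said of these compounds alone.

Measured in a functional assay on HCT-116 cells (Homo sapiens) for inhibition, read by CCK-8 assay, with a stated time of 48 h; a lower number here means a stronger inhibitor, a higher number a weaker inhibitor:
- compound 1 `COc1ccc(CN(C(=O)CSC(=S)N2CCN(C)CC2)c2cc(OC)c(OC)c(OC)c2)cc1`: 2640 nM
- compound 2 `CCN1CCN(C(=S)SCC(=O)N(Cc2ccc(OC)cc2)c2cc(OC)c(OC)c(OC)c2)CC1`: 7700 nM
- compound 3 `COc1ccc(CN(C(=O)CSC(=S)N2CCOCC2)c2cc(OC)c(OC)c(OC)c2)cc1`: 4130 nM

Compound 3 stands within the scatter of both other compounds: a 1.6-fold higher number from compound 1 to compound 3 (0.19 log units; within the scatter), and a 1.9-fold lower number from compound 2 to compound 3 (0.27 log units; within the scatter). These two steps exchange the ring on the same thiocarbonyl carbon as the change considered here, and neither goes beyond the scatter. Among the compounds with values here, the only step beyond it, a 2.9-fold higher number from compound 1 to compound 2 (0.46 log units; beyond the scatter), is modest and is a methyl in place of hydrogen, not an exchange of ring type.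

The unmeasured compound 4 `COc1ccc(CN(C(=O)CSC(=S)N2CCCC2)c2cc(OC)c(OC)c(OC)c2)cc1` differs from compound 3 as follows: pyrrolidin-1-yl in place of morpholin-4-yl on a thiocarbonyl carbon. Within the data shown here, no measured compound carries pyrrolidin-1-yl, so this ring is untested. With compound 3 at 4130 nM as the anchor, no step beyond the scatter is expected in this assay. The expected step is a 1.2-fold lower number from compound 3 to compound 4 (0.07 log units; within the scatter). The estimate for compound 4 is 3500 nM, with an expected range of 1500 nM to 8000 nM.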

Compound 4, half-maximal inhibitory concentration: 4970 nM
Estimate against measurement, compound 4: 1.4-fold (0.15 log units) below, within the range that was stated.
By their numbers in this assay, from the lowest: compounds 1, 3, 4 and 2 (each within the scatter of the next, the first and the last beyond it).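

In this assay, a five-membered ring with one hetero atom on this thiocarbonyl carbon stays within the scatter of the six-membered morpholin-4-yl ring (a 1.2-fold higher number from compound 3 to compound 4 (0.08 log units; within the scatter)). It also stays within the scatter of both piperazine rings (a 1.5-fold lower number from compound 2 to compound 4 (0.19 log units; within the scatter); a 1.9-fold higher number from compound 1 to compound 4 (0.27 log units; within the scatter)), although compound 1 and compound 2 lie beyond the scatter of each other, so the ring oxygen of compound 3 and the ring size are not needed to keep the number in this range for these four compounds. No measurement at hand explains this flat reading at the position.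

The compounds shown leave open how piperidin-1-yl, piperazin-1-yl without an alkyl group or an open-chain diethylamino group would read on this thiocarbonyl carbon. Also open, from the compounds shown here alone, is whether any such group gives a step beyond the scatter from compound 3.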